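Fluoro in place of chloro: expectation for compound 4

The compounds below may be only part of what the source reports. "The series", "measured", "known", "first", "only" and "open" are said of these compounds alone.

Compound 1 `N#Cc1c(F)c(Cl)c(C(C(=O)c2ccccc2)=C2NCCN2)c(C#N)c1F` and compound 2 `N#Cc1c(F)c(F)c(C(C(=O)c2ccccc2)=C2NCCN2)c(C#N)c1F` share one core; compound 3 `N#Cc1c(F)c(Cl)c(C(C(=O)c2ccc(F)cc2)=C2NCCCN2)c(C#N)c1F` and compound 4 `N#Cc1c(F)c(F)c(C(C(=O)c2ccc(F)cc2)=C2NCCCN2)c(C#N)c1F` share another, and the difference between the two cores is not broken down here. In a functional assay on HepG2 cells (Homo sapiens) for antiproliferative activity, read by MTT assay (a lower number here means a stronger inhibitor, a higher number a weaker inhibitor), compound 1 gives 32.6 ug/mL and compound 2 gives 9.1 ug/mL. The change between them is fluoro in place of chloro on an aromatic carbon, and it gives a 3.6-fold lower number from compound 1 to compound 2 (0.55 log units; beyond the scatter). In this assay compound 3 gives 45.1 ug/mL, which lies within the scatter of compound 1 and is a higher number than compound 2 shows. Compound 4 differs from compound 3 by fluoro in place of chloro on an aromatic carbon, the same change as that from compound 1 to compound 2, at a place described in the same words. For the measured compounds named here, a step of similar size is expected, a 3.6-fold lower number from compound 3 to compound 4 (0.56 log units; beyond the scatter), because the single measured instance of this change gave a 3.6-fold lower number from compound 1 to compound 2 (0.55 log units; beyond the scatter). Going by the values given here, with only one prior example, the range is kept wide. Compound 4 is estimated at 12.5 ug/mL in this assay, with a range from 5 ug/mL to 35 ug/mL.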

Compound 4, half-maximal inhibitory concentration: 11 ug/mL
Compound 4: the middle estimate sits 1.1-fold (0.06 log units) above what was measured; the range from low to high includes it.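

In this assay, fluoro in place of chloro on an aromatic carbon again gives a lower number, with a 4.1-fold lower number from compound 3 to compound 4 (0.61 log units; beyond the scatter), and the change carries from one core to the other with a step of matching size: the same change on two cores in this assay, a 3.6-fold lower number (0.55 log units; beyond the scatter) from compound 1 to compound 2 and a 4.1-fold lower number (0.61 log units; beyond the scatter) from compound 3 to compound 4, 1.1-fold (0.06 log units) apart, within the scatter of two such steps. For the compounds shown here, this agreement rests on only two pairs in one assay, so it covers the core of compound 1 and the core of compound 3 and cannot be extended to other cores or other read-outs. The pairs do not separate out what the difference between the two cores contributes, and they do not show why this change lowers the number.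

Left open is how groups other than fluoro and chloro, such as bromo, methoxy or an amine, would behave on this aromatic carbon. Also open, on these data alone, is whether the step keeps its size when a cyano group on the same ring gives way to a carboxylic acid.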